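The source may hold more compounds than are shown below. What is called first, only, known or untested is meant among the compounds shown, and "the series" means these compounds.

Working notes on the series, read in an ADME assay on THP-1 cells (Homo sapiens) for cytotoxicity, read by MTT assay, with a stated time of 72 h; on this read-out higher numbers stand for lower toxicity in this test and lower numbers for higher toxicity in this test. Compound 1 `C=C(C(=O)O)C(O)c1ccccc1Cl` gives > 100 uM, which is a limit of the assay and not a number. Compound 2 `C=C(Cc1ccccc1Cl)C(=O)OCC` gives > 100 uM, again only a limit. Among the measured compounds shown here, the series so far therefore stands at one shared mark: the limit of > 100 uM in this assay, at which 2 of the 2 values shown sit. For the measured compounds named here, no measured step is available to size a change in this assay.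

Compound 3 `C=C(Cc1ccccc1Cl)C(=O)O` carries hydrogen in place of ethyl on an oxygen next to a carbonyl group, the change from ethoxycarbonyl to carboxy: hydrogen in place of ethyl on an oxygen next to a carbonyl group. The expectation leans on compound 1, which also holds a carboxy group and gives > 100 uM, a limit. The expected change a step that the limit leaves unreadable from compound 2 to compound 3 is none beyond the scatter, and a further report as a limit is likely. For compound 3 the estimated value is 150 uM, with an expected range of 70 uM to 400 uM.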

Compound 3, half-maximal toxic concentration: > 100 uM
Compound 3 was reported as a limit; the forecaster's own chance of this, stated with the estimate: 75%; the middle value lies beyond the limit too.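

No step can be read among compound 1, compound 2 and compound 3 in this assay, and the series stays at one mark: the limit of > 100 uM in this assay, at which 3 of the 3 values shown sit.

The compounds shown leave open whether any change to this series gives a numerical value in this assay rather than a limit.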